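Amino to dimethylamino on compound 3

A few compounds are considered here, and "the series" means these few. Any claim that something is new, unique, unknown or untested is made for them only; others in the source may bear on it.

In a functional assay on MCF7 cells (Homo sapiens) for antiproliferative activity, read by MTT assay, with a stated time of 48 h (on this read-out lower numbers stand for stronger inhibition and higher numbers for weaker inhibition), compound 1 (`COc1ccc(C(=O)c2ccc(OC)c3c2C=CC(C)(C)O3)c(NC(=O)CBr)c1`) gives 3290 nM, compound 2 (`COc1ccc(C(=O)c2ccc(OC)c3c2OC(C)(C)C=C3)c(NC(=O)CN)c1`) gives 410 nM and compound 3 (`COc1ccc(C(=O)c2ccc3c(c2)C=CC(C)(C)O3)c(NC(=O)CN)c1`) gives 680 nM. Compound 3 thus reads within the scatter of compound 2 and beyond the scatter below compound 1. Compound 4 (`COc1ccc(C(=O)c2ccc3c(c2)C=CC(C)(C)O3)c(NC(=O)CN(C)C)c1`) departs from compound 3 by dimethylamino in place of amino on a saturated chain carbon bound to a carbonyl carbon, with dimethylamino in place of amino on a saturated chain carbon bound to a carbonyl carbon. Among the compounds with values here, no measured pair isolates this change, so direct evidence on its size is lacking. In this assay no step beyond the scatter is expected, and the estimated step is a 1.3-fold higher number from compound 3 to compound 4 (0.10 log units; within the scatter). For compound 4 the estimate is 850 nM, with an expected range of 300 nM to 2500 nM.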

Compound 4, half-maximal inhibitory concentration: 3560 nM
The estimate for compound 4 lay 4.2-fold (0.62 log units) below the measured number, and the stated range ends below it.
By their numbers in this assay, from the lowest: compounds 2 and 3 (each within the scatter of the next); then compounds 1 and 4 (each within the scatter of the next).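

In this assay, within the data shown here, the amino end of this chain proves sensitive to substitution: dimethylamino in place of amino gives a 5.2-fold higher number from compound 3 to compound 4 (0.72 log units; beyond the scatter), the first change read at a single place. The change removes the hydrogen-bond donor and adds heavy atoms together, and this one step cannot separate the two. No available evidence accounts for the step.

On these data alone, whether methylamino reads closer to amino or to dimethylamino stays open. Also open, as far as these compounds go, is whether pyrrolidine at this place, or the same change on the core of compound 2, would give a step of similar size.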